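Hydroxymethyl added to the side chain of compound 1

The compounds below may be only part of what the source reports. "The series", "measured", "known", "first", "only" and "open" are said of these compounds alone.

Compound 1 `CC(C)[C@@H]1NC(=O)[C@H](Cc2ccc(F)cc2)NC(=O)[C@H](Cc2ccc(Cl)cc2)NC(=O)CCCSC[C@@H](C(=O)N2CCC[C@H]2C(=O)NCCCCNC(=N)N)NC(=O)[C@H](CC(N)=O)NC1=O` gives 94% in an ADME assay on a cell-free system (plasma, Rattus norvegicus) for protein binding, read by LC-MS, with a stated time of 15 min
Compound 2 `CC(C)[C@@H]1NC(=O)[C@H](Cc2cccs2)NC(=O)[C@H](Cc2ccc(O)cc2)NC(=O)CCCSC[C@@H](C(=O)N2CCC[C@H]2C(=O)NCCCCN)NC(=O)[C@H](CC(N)=O)NC1=O` gives 42% in this assay
Compound 3 `CC(C)[C@@H]1NC(=O)[C@H](Cc2ccc(F)cc2)NC(=O)[C@H](Cc2ccc(Cl)cc2)NC(=O)CCCSC[C@@H](C(=O)N2CSC[C@H]2C(=O)NCCCCNC(=N)N)NC(=O)[C@H](CC(N)=O)NC1=O` gives 96% in this assay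

Compound 1 at 94% and compound 3 at 96% lie within the scatter of each other. Compound 2 at 42% stands well apart from them, but it differs from compound 1 in several places. Among the compounds with values here, no two measured compounds differ in one place only, so no single change has a measured size here.

Compound 4 `CC(C)[C@@H]1NC(=O)[C@H](Cc2ccc(F)cc2)NC(=O)[C@H](Cc2ccc(Cl)cc2)NC(=O)CCCSC[C@@H](C(=O)N2CCC[C@H]2C(=O)N[C@@H](CO)CCCNC(=N)N)NC(=O)[C@H](CC(N)=O)NC1=O` keeps the core of compound 1, and the change is hydroxymethyl in place of hydrogen on a saturated chain carbon bound to an amide-type nitrogen and a saturated chain carbon on a saturated chain carbon bound to an amide-type nitrogen and a saturated chain carbon. In this assay a small shift towards more free compound is expected, most likely none beyond the scatter. The expected change is a 1.3-fold higher unbound fraction from compound 1 to compound 4 (0.12 log units; within the scatter) on this estimate. For compound 4 the estimated value is 92% within an expected range of 85% to 97% as the working figure.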

Compound 4, plasma protein binding: 93%
Estimate against measurement, compound 4: 1.1-fold (0.06 log units) (unbound fraction) above; the measured number falls inside the stated range.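

Within the data shown here, this is the first step with a single change, which the earlier compounds could not provide. In this assay, hydroxymethyl in place of hydrogen on a saturated chain carbon bound to an amide-type nitrogen and a saturated chain carbon gives a 1.2-fold higher unbound fraction from compound 1 to compound 4 (0.07 log units; within the scatter), so at this position this change leaves the read-out within the scatter. Nothing available bears on the reason for this result.

As far as these compounds go, whether an amine, a carboxylic acid or a longer chain at the same place would give a step beyond the scatter in this assay remains open. From the compounds shown here alone, it also remains open whether hydroxymethyl would give a similar step on compound 3, or on compound 2, which stands well apart from compound 1 in its value.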